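Pyridinyl Vinyl Sulfones: Moving the Ring Nitrogen

The source may hold more compounds than are shown below. What is called first, only, known or untested is meant among the compounds shown, and "the series" means these compounds.

The series rests on a shared core carrying a methoxyphenylsulfonyl group joined through a double bond to a pyridine ring. Compound 1 `COc1cccc(S(=O)(=O)/C=C/c2cccnc2)c1` and compound 2 `COc1ccc(S(=O)(=O)/C=C/c2cccnc2)cc1` differ in their cores; the difference between the two cores is not broken down here. In an assay on U2OS cells for activation of nuclear factor erythroid 2-related factor 2 (Homo sapiens), read by chemiluminescence, with a stated time of 6 h (on this read-out lower numbers stand for an effect already at smaller amounts and higher numbers for an effect only at larger amounts of compound), compound 1 gives 6290 nM. In this assay compound 2 reaches only a limit of the assay, > 10000 nM, which is the limit (the limit of > 10000 nM in this assay, at which 1 of the 3 values shown sits).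

Compound 3 `COc1cccc(S(=O)(=O)/C=C/c2ccncc2)c1` arises from compound 1 by the change (pyridin-4-yl in place of pyridin-3-yl on a double-bonded chain carbon bound to a double-bonded chain carbon). In this assay compound 3 gives 655 nM, a step of a 9.6-fold lower number from compound 1 to compound 3 (0.98 log units; beyond the scatter).

Compound 4 `COc1ccc(S(=O)(=O)/C=C/c2ccncc2)cc1` is not yet measured. It arises from compound 2 by the same kind of change, (pyridin-4-yl in place of pyridin-3-yl on a double-bonded chain carbon bound to a double-bonded chain carbon), made on the core of compound 2. If that change carries over, a step of about an at least 4.0-fold lower number from compound 2 to compound 4 (0.60 log units; beyond the scatter) is expected from compound 2 to compound 4 in this assay, resting on the step of a 9.6-fold lower number from compound 1 to compound 3 (0.98 log units; beyond the scatter) seen on the other core. Compound 4 is therefore estimated at 2500 nM in this assay, with a range from 700 nM to 10000 nM, allowing that compound 2 is known only as a limit > 10000 nM.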

Compound 4, half-maximal effective concentration: 1200 nM
Estimate against measurement, compound 4: 2.1-fold (0.32 log units) above; low and high end bracket the measured number.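

In this assay, pyridin-4-yl in place of pyridin-3-yl also goes with a lower number on the second core, an at least 8.3-fold lower number from compound 2 to compound 4 (0.92 log units; beyond the scatter). The value of compound 2, > 10000 nM, is a limit of the assay. The change therefore runs in the same direction on both cores, but this does not show that it has the same size on each, and two cores cannot show how it would behave on any other core: the same change on two cores in this assay, a 9.6-fold lower number (0.98 log units; beyond the scatter) from compound 1 to compound 3 and an at least 8.3-fold lower number (0.92 log units; beyond the scatter) from compound 2 to compound 4; the limit leaves it open whether they differ

As far as these compounds go, how pyridin-2-yl would compare on either core remains open, as does the effect of an amine or a carboxylic acid in place of the methoxy group. The compounds shown also leave open whether these results hold in any read-out other than this assay.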